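A few compounds are considered here, and "the series" means these few. Any claim that something is new, unique, unknown or untested is made for them only; others in the source may bear on it.

Of the compounds shown here, three from this series have so far been tested in a toxicity assay on the whole organism (strain Icem-CET (SPF Caw)) for cytotoxicity, with Mus musculus as the target; on this read-out higher numbers stand for an effect only at larger amounts of compound and lower numbers for an effect already at smaller amounts. Compound 1 `COc1ccc(/C(C)=C(\C)C(=O)NC2CC2)cc1` gives 300 mg/kg, a number that sits between those of the other two: compound 3 `C=CCNC(=O)/C(C)=C(/C)c1ccc(Cl)cc1` gives 280 mg/kg and compound 2 `C#CCNC(=O)/C(C)=C(\C)c1ccc(OC)cc1` gives 400 mg/kg, and both gaps from compound 1 are within the usual scatter, so none of the three can be set apart from the others. Among the compounds with values here, the only change tracked between measured compounds is a propargyl in place of a cyclopropyl on an amide-type nitrogen, which gave a 1.3-fold higher number from compound 1 to compound 2 (0.12 log units; within the scatter).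

Compound 4 `C/C(C(=O)NC1CC1)=C(/C)c1ccc(C)cc1` has not yet been measured. It differs from compound 1 in a single place: methyl in place of methoxy on an aromatic carbon. Within the data shown here, no measured pair in this set probes that part of the core. Among the measured compounds shown here, compound 3 differs from compound 1 in more than one place, so its value cannot be read as the effect of one change, and the one tracked step concerns the nitrogen substituent, not the ring. With nothing pointing toward a shift, the step of no change at the digits printed from compound 1 to compound 4 (within the scatter) is expected to remain within the scatter, in no particular direction. Compound 4 is therefore estimated at 300 mg/kg in this assay, with a range from 170 mg/kg to 530 mg/kg.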

Compound 4, dose for half-maximal effect: 300 mg/kg
For compound 4 middle estimate and measured number coincide at the digits printed, within the range that was stated.
By their numbers in this assay, from the lowest: compounds 3, 1, 4 and 2 (each within the scatter of the next).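

In this assay, within the data shown here, methyl in place of methoxy on an aromatic carbon, para to a large group, gives no change at the digits printed from compound 1 to compound 4 (within the scatter) and so provides the first single-place reading on the aromatic ring, where the earlier tracked step concerned only the group on the amide nitrogen. This change takes away the oxygen of methoxy and, with it, the one hydrogen-bond acceptor counted for that group, yet the two compounds cannot be told apart on this toxicity read-out, so at this place the acceptor is not required for a number of this size. No separate measurement here bears on why methoxy and methyl read alike.

As far as these compounds go, the comparison at this place covers only methoxy and methyl, so it remains open whether an amine, a carboxylic acid or a longer chain there would also stay within the scatter of compound 1. From the compounds shown here alone, it also remains open whether the same exchange would read alike with propargyl rather than cyclopropyl on the amide nitrogen.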